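Compound 3 after a hydroxyphenyl swap

The compounds below may be only part of what the source reports. "The series", "measured", "known", "first", "only" and "open" are said of these compounds alone.

Compounds measured so far in a functional assay on HepG2 cells (Homo sapiens) for antiproliferative activity, read by sulforhodamine B assay, with a stated time of 48 h; a lower number here means a stronger inhibitor, a higher number a weaker inhibitor
- compound 1 `COc1cccc(/C=C/C(=O)C(=Cc2ccc(F)cc2)C(=O)/C=C/c2cccc(OC)c2OC)c1OC` gives 580 nM
- compound 2 `COc1cccc(/C=C/C(=O)C(=Cc2ccc(O)c(F)c2)C(=O)/C=C/c2cccc(OC)c2OC)c1OC` gives 220 nM

Compound 2 holds the lowest number of the two, and its gap to compound 1 lies beyond the scatter. Compound 3 `COc1ccc(C=C(C(=O)/C=C/c2cccc(OC)c2OC)C(=O)/C=C/c2cccc(OC)c2OC)cc1O` has 3-hydroxy-4-methoxyphenyl in place of 3-fluoro-4-hydroxyphenyl on a double-bonded chain carbon bound to a double-bonded chain carbon. Within the data shown here, the one measured step bearing on this is modest, a 2.6-fold lower number from compound 1 to compound 2 (0.42 log units; beyond the scatter) when 3-fluoro-4-hydroxyphenyl replaced 4-fluorophenyl. Among the measured compounds shown here, no measured step exchanges the two groups now in question, so it offers only loose guidance. Compound 3 keeps a hydroxy group on the phenyl, as compound 2 does, and compound 1 has none. In this assay the expected change is a 1.1-fold higher number from compound 2 to compound 3 (0.06 log units; within the scatter) and thus nothing beyond the scatter. The estimate for compound 3 is 250 nM with an expected range from 90 nM to 700 nM in this measurement.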

Compound 3, half-maximal inhibitory concentration: 270 nM
Beside the measured number, compound 3's estimate is 1.1-fold (0.03 log units) below it, within the range that was stated.
By their numbers in this assay, from the lowest: compounds 2 and 3 (each within the scatter of the next); then compound 1.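

In this assay, the exchange of 3-fluoro-4-hydroxyphenyl for 3-hydroxy-4-methoxyphenyl gives a 1.2-fold higher number from compound 2 to compound 3 (0.09 log units; within the scatter), so at this position on a double-bonded chain carbon the two groups cannot be told apart, even though one carries fluorine and the other methoxy. The second step, a 2.1-fold lower number from compound 1 to compound 3 (0.33 log units; beyond the scatter), shows that a group without fluorine also stands apart from 4-fluorophenyl, and among these three compounds both groups bearing a hydroxy give lower numbers than the one without it, with no compound going against this. Nothing available explains these differences.

Each step away from compound 1 changes more than the hydroxy group alone, so its own share in the gap remains unresolved. From the compounds shown here alone, how a plain 4-hydroxyphenyl, or an amine or carboxylic acid on the phenyl in place of the hydroxy, would read in this assay also remains open.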